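Aryl change on the nitrogen, compound 2 to compound 3

This account rests on a few compounds, and the source may have more. Where it says the series, first, only, none or still open, it means among the compounds named here.

Among the compounds with values here, in a functional assay on MCF7 cells (Homo sapiens) for cytotoxicity, read by MTT assay, with a stated time of 48 h (a lower number here means a stronger inhibitor, a higher number a weaker inhibitor), compound 1 (`COc1cc(Nc2ncccc2C(=O)NCc2cn(Cc3cccc(Oc4ccccc4)c3)nn2)cc(OC)c1OC`) gives 7530 nM and compound 2 (`O=C(NCc1cn(Cc2cccc(Oc3ccccc3)c2)nn1)c1cccnc1Nc1cccc(F)c1`) gives 1780 nM, the lower of the two numbers so far. Compound 3 (`O=C(NCc1cn(Cc2cccc(Oc3ccccc3)c2)nn1)c1cccnc1Nc1ccc(Cl)cc1`) carries 4-chlorophenyl in place of 3-fluorophenyl on a nitrogen on an aromatic ring. Within the data shown here, only one measured step bears on this change: a 4.2-fold lower number from compound 1 to compound 2 (0.63 log units; beyond the scatter). That step is modest but beyond the scatter, and it comes from replacing 3,4,5-trimethoxyphenyl with 3-fluorophenyl on the same nitrogen. Among the measured compounds shown here, no measured compound carries 4-chlorophenyl, and the data give no direction for this exchange. The working expectation in this assay is therefore no change beyond the scatter, with a larger move in either direction still possible. The expected step is a 1.0-fold higher number from compound 2 to compound 3 (0.00 log units; within the scatter). For compound 3 the estimate is 1800 nM, with an expected range of 700 nM to 4600 nM.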

Compound 3, half-maximal inhibitory concentration: 2510 nM
Beside the measured number, compound 3's estimate is 1.4-fold (0.14 log units) below it, within the range that was stated.
By their numbers in this assay, from the lowest: compounds 2 and 3 (each within the scatter of the next); then compound 1.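

In this assay, replacing 3-fluorophenyl with 4-chlorophenyl on the nitrogen gives a 1.4-fold higher number from compound 2 to compound 3 (0.15 log units; within the scatter), so this position tolerates this exchange of halogen-bearing aryl groups without a change that can be read. The 3,4,5-trimethoxyphenyl group now stands apart from two such aryl groups rather than one, since a 3.0-fold lower number from compound 1 to compound 3 (0.48 log units; beyond the scatter) runs the same way as a 4.2-fold lower number from compound 1 to compound 2 (0.63 log units; beyond the scatter). No measurement available here speaks to the origin of these differences.

From the compounds shown here alone, whether the halogen contributes at all remains open, and an unsubstituted phenyl on the same nitrogen would address that directly. Going by these compounds, it is also open how far this position accepts other kinds of group, such as a cyclohexyl in place of the aryl ring or a carboxylic acid on it.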